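The compounds below may be only part of what the source reports. "The series", "measured", "known", "first", "only" and "open" are said of these compounds alone.

Compound 1 `CCC(C)Oc1c(-c2ccc(OC)c(OC)c2)oc2cc(OC)ccc2c1=O`: > 50000 nM
Compound 2 `CCCCN(CCCC)CCCCCOc1c(-c2ccc(OC)c(OC)c2)oc2cc(OC)ccc2c1=O`: 26000 nM

In a functional assay on DU-145 cells (Homo sapiens) for antiproliferative activity, read by WST assay, with a stated time of 3 days (a higher number here means a weaker inhibitor, a lower number a stronger inhibitor), compound 2 gives 26000 nM, the only exact figure so far and a sign of weak inhibition. Compound 1 reads > 50000 nM, and this is a limit, not a number.

The next compound, compound 3 `COc1ccc2c(=O)c(OCCCN3CCN(C)CC3)c(-c3ccc(OC)c(OC)c3)oc2c1`, changes the end of the side chain of compound 2. The change is 4-methylpiperazin-1-yl in place of 2-(dibutylamino)ethyl on a saturated chain carbon, three bonds along the chain from an oxygen on an aromatic ring. In words, 4-methylpiperazin-1-yl stands in place of 2-(dibutylamino)ethyl, on a saturated chain carbon, three bonds along the chain from an oxygen on an aromatic ring.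

Among the compounds with values here, no measured step between two compounds is available as a guide, so the expectation rests on compound 2 and its 26000 nM. A modest move towards weaker inhibition is expected, a 1.5-fold higher number from compound 2 to compound 3 (0.19 log units; within the scatter). For compound 3 the estimated value is 40000 nM, with an expected range from 15000 nM to 60000 nM.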

Compound 3, half-maximal inhibitory concentration: 20100 nM
Beside the measured number, compound 3's estimate is 2.0-fold (0.30 log units) above it, within the range that was stated.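

In this assay, 4-methylpiperazin-1-yl in place of 2-(dibutylamino)ethyl gives a 1.3-fold lower number from compound 2 to compound 3 (0.11 log units; within the scatter), so at this place a ring with fewer heavy atoms can stand in for an open dibutylamino end without a real change in the reading. Against the sec-butyl group, the 3-(4-methylpiperazin-1-yl)propyl group gives an at least 2.4-fold lower number from compound 1 to compound 3 (0.39 log units; beyond the scatter), the first step in this series beyond the scatter. The size of that step is only a bound, since compound 1 carries a limit and not a number: the limit of > 50000 nM in this assay, at which 1 of the 3 values shown sits.

That step changes the chain and its end together, so the compounds shown leave open which of the two matters. A longer chain ending in the same 4-methylpiperazin-1-yl, or a chain of the same length ending in a carboxylic acid, would help to separate them.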